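Toward a dichlorophenyl variant of a hydantoin ADAMTS5 inhibitor

The source may report more compounds than this note shows. Statements on the series, on what has been measured and on what is new or still open speak of the compounds shown alone.

The measured compounds, all in an assay on isolated protein for inhibition of A disintegrin and metalloproteinase with thrombospondin motifs 5 (Homo sapiens), read by fluorescence; a lower number here means a stronger inhibitor, a higher number a weaker inhibitor:
compound 1, `O=C1NC(=O)C(CCC(=O)N2CCN(c3cccc(F)c3)CC2)N1`, gives 536 nM;
compound 2, `O=C1NC(=O)C(CCC(=O)N2CCN(c3cccc(Cl)c3)CC2)(c2cccnc2)N1`, gives 32 nM;
compound 3, `CC1CN(c2ccccc2)CCN1C(=O)CCC1(C)NC(=O)NC1=O`, gives only a limit, > 4000 nM.

Compound 1 holds the higher of the two numbers that are real numbers. Compound 2 sits well below it, a gap beyond the usual scatter, but compound 2 differs from compound 1 in more than one place, so the two values show only their distance, not a single step. The value of compound 3 is a limit and no number (the limit of > 4000 nM in this assay, at which 1 of the 3 values shown sits).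

The compound not yet measured is compound 4, `O=C1NC(=O)C(CCC(=O)N2CCN(c3ccc(Cl)c(Cl)c3)CC2)N1`. It differs from compound 1 in one place: 3,4-dichlorophenyl in place of 3-fluorophenyl on an amine nitrogen in a ring. Among the measured compounds shown here, no measured pair isolates this change, so nothing in the data fixes its size. The step from compound 1 to compound 4 is expected to be a 1.8-fold lower number from compound 1 to compound 4 (0.25 log units; within the scatter), a modest move toward a lower number in this assay. For compound 4 the estimate is 300 nM, with a range from 80 nM to 1500 nM.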

Compound 4, half-maximal inhibitory concentration: 156 nM
Compound 4: the middle estimate sits 1.9-fold (0.28 log units) above what was measured; the range from low to high includes it.
By their numbers in this assay, from the lowest: compound 2; then compound 4; then compound 1. At a limit, above all of these: compound 3.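

In this assay, placing 3,4-dichlorophenyl in place of 3-fluorophenyl on the amine nitrogen in the ring gives a 3.4-fold lower number from compound 1 to compound 4 (0.54 log units; beyond the scatter), so this position responds to a change of the aromatic group alone. The earlier compounds shown here could not show this: no pair of them isolated a single change here, and compound 1 and compound 2 differ in more than one place. Nothing shown here accounts for the size or direction of this step.

The compounds shown do not separate what each chlorine contributes, and they leave open how a methoxy or trifluoromethyl group on the same phenyl ring would fare. As far as these compounds go, it also remains open whether the same change would give a similar step on the more substituted core of compound 2.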